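Geometric isomers of a thioether citrate analogue

The source may report more compounds than this note shows. Statements on the series, on what has been measured and on what is new or still open speak of the compounds shown alone.

Measured so far, all in an assay on isolated protein for inhibition of ATP-citrate synthase (Rattus norvegicus); a lower number here means a stronger inhibitor, a higher number a weaker inhibitor:

compound 1, `O=C(O)CC(O)(CSCCCCCCc1ccc(Cl)c(Cl)c1)C(=O)O`, gives 110000 nM
compound 2, `O=C(O)CCCSCCCCCCc1ccc(Cl)cc1Cl`, gives 25000 nM
compound 3, `O=C(O)CC(O)(CSCCCC/C=C/c1ccc(Cl)cc1Cl)C(=O)O`, gives 7400 nM

Compound 3 holds the lowest number of the three; the nearest is compound 2, whose number lies beyond the scatter above it, and compound 1 lies further still. No pair among these three differs in only one place, so no single-change step is available as a guide.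

Compound 4, `O=C(O)CC(O)(CSCCCC/C=C\c1ccc(Cl)cc1Cl)C(=O)O`, is the unmeasured partner of compound 3. The difference is the two compounds have the same atoms and bonds; at least one stereo element is drawn with a configuration in one of them and without one in the other: 1 of 2 stereo elements differ; a double bond is drawn E in compound 3 and Z in compound 4. Nothing in the series shows what a switch of double-bond geometry alone does in this assay , so the expectation rests on compound 3 alone. A change of this kind is expected to be small, with a slight lean toward a weaker inhibitor, and is estimated to stay near the scatter.

For compound 4 the estimate is 10000 nM, with a range of 3500 nM to 30000 nM, which corresponds to an expected step of a 1.4-fold higher number from compound 3 to compound 4 (0.13 log units; within the scatter).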

Compound 4, inhibition constant: 33000 nM
Compound 4: middle estimate off by 3.3-fold (0.52 log units), on the low side; the measured number lies above the stated range.
By their numbers in this assay, from the lowest: compound 3; then compounds 2 and 4 (each within the scatter of the next); then compound 1.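

Double-bond geometry alone moves the number in this assay: the switch from E to Z gives a 4.5-fold higher number from compound 3 to compound 4 (0.65 log units; beyond the scatter). For the compounds shown here, this is the first single-change step, and it places the E form, compound 3, ahead of its Z partner, so the same atoms and bonds do not by themselves set the number at this position. The reading of this step carries one structural qualification: the fact that one of compounds 3 and 4 is drawn with a defined configuration and the other without, at the place where they differ

On these data alone, it remains open whether the same preference for E holds with a longer chain between the sulfur and the double bond, or with different ring substitution. Also open, as far as these compounds go, is how a triple bond in place of the double bond would compare with either geometric isomer in this assay.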